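A few compounds are considered here, and "the series" means these few. Any claim that something is new, unique, unknown or untested is made for them only; others in the source may bear on it.

Compound 1 `Cn1c(-c2ccc(NC(=O)CSC3=NCCS3)cc2)nc(-c2ccccc2)c1-c1ccccc1` gives 30.4% in a functional assay on HT-29 cells (Homo sapiens) for cytotoxicity, read by MTT assay, with a stated time of 24 h, tested at 1.6 ug/mL; on this read-out higher numbers stand for a stronger effect at the one concentration tested and lower numbers for a weaker effect. Compound 2 `Cn1ccnc1SCC(=O)Nc1ccc(-c2nc(-c3ccccc3)c(-c3ccccc3)n2C)cc1` gives 23.8% in this assay. Compound 3 `CN(C)/C=C/N1CCN(CC(=O)Nc2ccc(-c3nc(-c4ccccc4)c(-c4ccccc4)n3C)cc2)CC1` gives 8% in this assay.

Compound 3 stands lowest of the three numbers; the step of a number 15.8 percentage points lower from compound 2 to compound 3 (beyond the scatter) is beyond the scatter, and the step of a number 22.4 percentage points lower from compound 1 to compound 3 (beyond the scatter) is larger still, so compound 3 sits clearly under both neighbours. Compound 4 `Cn1c(-c2ccc(NC(=O)CN3CCN(Cc4ccc(Cl)cc4)CC3)cc2)nc(-c2ccccc2)c1-c1ccccc1` differs from compound 3 by 4-chlorobenzyl in place of 2-(dimethylamino)ethenyl on an amine nitrogen in a ring. For the measured compounds named here, no measured step touches this position: a number 6.6 percentage points lower from compound 1 to compound 2 (within the scatter) and a number 15.8 percentage points lower from compound 2 to compound 3 (beyond the scatter) both concern the group on the saturated chain carbon bound to the carbonyl carbon, and the six-membered non-aromatic ring with two nitrogen occurs only in compound 3. Going by the values given here, the data therefore offer no step of the same kind on which to rest a firm expectation, only the observation that the exchanges measured so far shifted the read-out by modest amounts. For compound 4 a small rise is expected, estimated as a number 6 percentage points higher from compound 3 to compound 4 (within the scatter), with wide uncertainty in either direction. Compound 4 is estimated at 14%, within 2% to 35%.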

Compound 4, a percentage reported as activity, at one concentration (the size of the read-out at that concentration, not a potency): 16.4%
Beside the measured number, compound 4's estimate is 2.4 percentage points below it, within the range that was stated.
By their numbers in this assay, from the lowest: compounds 3, 4, 2 and 1 (each within the scatter of the next, the first and the last beyond it).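

On the amine nitrogen in the ring of the six-membered non-aromatic ring, 4-chlorobenzyl in place of 2-(dimethylamino)ethenyl gives a number 8.4 percentage points higher from compound 3 to compound 4 (within the scatter) in this assay. For the compounds shown here, this is the first reading at this position, as the earlier steps concerned only the group on the saturated chain carbon bound to the carbonyl carbon, and it shows that a group with a six-membered aromatic ring of carbon only, and no double bond outside aromatic rings, does not separate from the open chain on this read-out. No supporting data bear on this result.

Open, going by these compounds, is whether a plain benzyl, a methyl or a hydrogen on this nitrogen would read differently from these two groups. Also open, on these data alone, is whether a carboxylic acid on a longer chain at this nitrogen would move the number beyond the scatter.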